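Chloro for hydrogen on the amide aryl ring

The source may hold more compounds than are shown below. What is called first, only, known or untested is meant among the compounds shown, and "the series" means these compounds.

Compound 1 `O=C(CCCCC(S)CCS)Nc1ccccc1` carries a phenyl on the amide nitrogen; compound 2 `O=C(CCCCC(S)CCS)Nc1ccc(Cl)cc1` is its chloro analogue. In a functional assay on Bel-7402 cells (Homo sapiens) for inhibition, read by MTT assay, with a stated time of 24 h, tested at 10 ug/mL (on this read-out higher numbers stand for more inhibition of growth at the one concentration tested and lower numbers for less inhibition of growth), compound 1 gives 3.72%. In the same read-out compound 2 gives 1.16%. The change between them is chloro in place of hydrogen on an aromatic carbon, and the step it made is a number 2.6 percentage points lower from compound 1 to compound 2 (within the scatter); the two values show nothing that the assay can tell apart.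

Compound 3 `O=C(CCCCC(S)CCS)Nc1ccccn1` differs from compound 1 in its core: pyridin-2-yl in place of phenyl on an amide-type nitrogen. In this assay compound 3 is reported as "not active" (no number reported), with no single number given.

Compound 4 `O=C(CCCCC(S)CCS)Nc1ccc(Cl)cn1` stands to compound 3 as compound 2 stands to compound 1: chloro in place of hydrogen on an aromatic carbon. This is the same kind of change, though the place is not the same word for word: in compound 1 the chloro enters on a six-membered aromatic ring of carbon only, para to a large group; in compound 3 it enters on a six-membered aromatic ring with 1 nitrogen, two atoms from the ring nitrogen, para to a large group.

In this assay the step from compound 3 to compound 4 is expected to be of the same small size as the earlier one, within the scatter, because the earlier step was a number 2.6 percentage points lower from compound 1 to compound 2 (within the scatter) and compound 3 itself gave no measurable inhibition. Since compound 3 has no number, a sizeable chance remains that compound 4 is also reported without one. Compound 4 is estimated at 2%, with an expected range from -8% to 12%.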

Compound 4, percent growth inhibition at one concentration: 17.8%
Beside the measured number, compound 4's estimate is 15.8 percentage points below it; measured number outside the range, above it.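

In this assay, within the data shown here, compound 3 stands as "not active" (no number reported) and compound 4 gives 17.8% so no step from compound 3 to compound 4 can be read. No measured information available here accounts for the number of compound 4. The compounds shown leave open how far chloro on this ring shifts growth inhibition, and whether that shift would hold at other concentrations.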